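Working notes: from compound 2 to compound 3

The source may report more compounds than this note shows. Statements on the series, on what has been measured and on what is new or still open speak of the compounds shown alone.

- compound 1 `Cc1ccc(/C=N/c2ccccc2C(=O)NNc2ccnc3cc(Cl)ccc23)cc1`: 5.31
- compound 2 `COc1ccc(/C=N/c2ccccc2C(=O)NNc2ccnc3cc(Cl)ccc23)cc1OC`: 4.97

Both values come from a physicochemical assay for lipophilicity, measured as octanol-water partition; on this read-out lower numbers stand for lower lipophilicity and higher numbers for higher lipophilicity. Going by the values given here, of the two numbers so far, compound 2 holds the lower one, and compound 1 sits above it, beyond the scatter.

The next structure is compound 3 `O=C(NNc1ccnc2cc(Cl)ccc12)c1ccccc1/N=C/c1ccc(O)cc1`, with 4-hydroxyphenyl in place of 3,4-dimethoxyphenyl on a carbon with a double bond to nitrogen.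

Among the compounds with values here, only one measured step bears on this change, and it was made at the same place: a number 0.34 log units lower from compound 1 to compound 2 (beyond the scatter). That step was modest. Within the data shown here, no measured compound yet carries 4-hydroxyphenyl, so the single step is a weak guide. On the basis of that step, a modest move to a lower number in this assay is expected, perhaps somewhat larger than the step already seen.

The expected change is a number 0.37 log units lower from compound 2 to compound 3 (beyond the scatter). For compound 3 the estimated value is 4.6, with an expected range from 4.1 to 5.1.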

Compound 3, partition coefficient: 4.65
Beside the measured number, compound 3's estimate is 0.05 log units below it, within the range that was stated.
By their numbers in this assay, from the lowest: compound 3; then compound 2; then compound 1.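

In this assay, the substituted phenyl on the carbon with a double bond to nitrogen now gives a second downward step, a number 0.32 log units lower from compound 2 to compound 3 (beyond the scatter) as 4-hydroxyphenyl, with 7 heavy atoms and 1 hydrogen-bond donor, replaces 3,4-dimethoxyphenyl, with 10 heavy atoms and 0 hydrogen-bond donors. The series also gains a direct exchange of hydroxy for methyl on an aromatic carbon, a number 0.66 log units lower from compound 1 to compound 3 (beyond the scatter) and the lowest of the three numbers now belongs to the hydroxy compound. No measurement at hand explains either step.

The three compounds cannot separate the effect of the hydroxy group from that of removing both methoxy groups. On these data alone, whether an amine or a carboxylic acid at this place on the phenyl would continue the downward run remains open.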